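A few compounds are considered here, and "the series" means these few. Any claim that something is new, unique, unknown or untested is made for them only; others in the source may bear on it.

Of the compounds shown here, three built on one shared core have been tested in a functional assay (Cavia porcellus) with sulfonylurea receptors; K-ATP channels (Homo sapiens) as the target; a higher number here means a weaker inhibitor, a lower number a stronger inhibitor. Compound 1 `CC(O)(C(=O)Nc1ccc(C(=O)c2ccccc2)cc1F)C(F)(F)F` gives 11000 nM, compound 2 `CC(O)(C(=O)Nc1ccc(C(=O)c2ccccc2)cc1C#N)C(F)(F)F` gives 3800 nM, and compound 3 `CC(O)(C(=O)Nc1ccc(C(=O)c2ccccc2)cc1O)C(F)(F)F` gives 15000 nM. Among these three, compound 3 carries the highest number; the steps leading to it read a 1.4-fold higher number from compound 1 to compound 3 (0.13 log units; within the scatter) and a 3.9-fold higher number from compound 2 to compound 3 (0.60 log units; beyond the scatter), so compound 3 is clearly set apart only from compound 2, while the gap to compound 1 lies within the scatter.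

Compound 4 `COc1cc(C(=O)c2ccccc2)ccc1NC(=O)C(C)(O)C(F)(F)F` differs from compound 3 in a single place: methyl in place of hydrogen on an oxygen on an aromatic ring. Among the measured compounds shown here, none of the measured steps touches a methyl on this oxygen. The steps that do exist exchange the whole group on the aromatic carbon, namely a 2.9-fold lower number from compound 1 to compound 2 (0.46 log units; beyond the scatter) as well as the two steps already given, and they show that this position can shift the number by a modest amount at most. For the measured compounds named here, with no direct precedent for capping the hydroxy as a methoxy, the step from compound 3 is expected to be a 1.3-fold lower number from compound 3 to compound 4 (0.10 log units; within the scatter), most likely not beyond the scatter. Compound 4 is therefore estimated at 12000 nM, with a range from 4000 nM to 35000 nM.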

Compound 4, half-maximal inhibitory concentration: 6100 nM
For compound 4 the middle estimate is 2.0-fold (0.29 log units) above the measured one, within the range that was stated.
By their numbers in this assay, from the lowest: compounds 2, 4, 1 and 3 (each within the scatter of the next, the first and the last beyond it).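

In this assay, among the compounds shown here, the single added methyl makes a real difference: the step is a 2.5-fold lower number from compound 3 to compound 4 (0.39 log units; beyond the scatter) and it shows that capping the hydroxy as a methoxy moves the number by a modest amount, whereas the earlier steps only exchanged the whole group on the aromatic carbon. Compared with those other groups, the methoxy cannot be told apart from either of them, since a 1.6-fold higher number from compound 2 to compound 4 (0.21 log units; within the scatter) and a 1.8-fold lower number from compound 1 to compound 4 (0.26 log units; within the scatter) are both within the scatter, so this position tolerates cyano, fluoro and methoxy with no clear separation among the three pairs involving compound 4 except the one to compound 3. No measurement at hand speaks to the reason for the step from the hydroxy to the methoxy.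

The compounds shown leave open whether a longer chain on this oxygen, such as an ethoxy, would carry the number further down or bring it back up. They also do not tell how an amine or a carboxylic acid on this aromatic carbon would compare with the four groups seen so far, or whether any group here can move the number by more than a modest amount.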